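The source may hold more compounds than are shown below. What is called first, only, known or untested is meant among the compounds shown, and "the series" means these compounds.

Compound 1 `CC1=CSC2=NC(/C=C/c3ccccc3)=C(C(=O)/C=C/c3ccccc3)C(c3ccccc3)N12` and compound 2 `COc1cc(/C=C/C(=O)C2=C(/C=C/c3cc(OC)c(OC)c(OC)c3)N=C3SC=C(C)N3C2c2ccccc2)cc(OC)c1OC` share a core and were tested in an ADME assay on Vero cells (Chlorocebus sabaeus) for cytotoxicity, read by fluorescence and resazurin assay, with a stated time of 72 h; on this read-out higher numbers stand for lower toxicity in this test and lower numbers for higher toxicity in this test. In this assay compound 1 gives 195 ug/mL, and compound 2 gives 260 ug/mL. Among these two numbers compound 1 holds the lower one, while compound 2 sits close to it, within the usual scatter, so the two values show no separation that can be read as a difference in cytotoxicity.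

Compound 3 `COc1ccc(C2C(C(=O)/C=C/c3ccccc3)=C(/C=C/c3ccccc3)N=C3SC=C(C)N32)cc1` has not yet been measured in this assay. It differs from compound 1 in one place: methoxy in place of hydrogen on an aromatic carbon, which means that a methoxy takes the place of a hydrogen on an aromatic carbon. Within the data shown here, no step between two measured compounds covers this exact change, so the expectation can rest only on what the two measured values show. Since compound 2, which carries several methoxy groups, gives 260 ug/mL and lies within the scatter of compound 1, the step of a 1.1-fold higher number from compound 1 to compound 3 (0.04 log units; within the scatter) is expected to be small, if anything a slight rise, and not beyond the scatter. Compound 3 is therefore estimated at 215 ug/mL, within a range from 120 ug/mL to 380 ug/mL.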

Compound 3, half-maximal cytotoxic concentration: 211 ug/mL
Estimate against measurement, compound 3: 1.0-fold (0.01 log units) above; low and high end bracket the measured number.
By their numbers in this assay, from the lowest: compounds 1, 3 and 2 (each within the scatter of the next).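

In this assay, the change from phenyl to 4-methoxyphenyl gives a 1.1-fold higher number from compound 1 to compound 3 (0.03 log units; within the scatter), so this single change, para to a large group, produces no separation from the parent that can be read as a difference in cytotoxicity. Among these compounds, this is the first step that isolates a single place, something compound 1 and compound 2 could not do, since they differ in more than one place and their close values say nothing about any one methoxy group. Nothing available explains why this position tolerates the change, so the result stands as an observation only.

What the compounds shown leave open is whether this tolerance belongs to methoxy alone or extends to quite different groups at the same carbon, such as an amine, a carboxylic acid or a longer alkoxy chain. On these data alone, it also remains open whether the same step would look alike on a background carrying the other methoxy groups of compound 2, as a single change at this position has been read only against compound 1.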